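This account rests on a few compounds, and the source may have more. Where it says the series, first, only, none or still open, it means among the compounds named here.

Three compounds built on the shared core of compound 1, `O=C(CSc1nncnc1-c1cccc2ccccc12)Nc1ccc([N+](=O)[O-])cc1Cl`, have been tested in an ADME assay on MT4 cells (Homo sapiens) for cytotoxicity, read by MTT assay; on this read-out lower numbers stand for higher toxicity in this test and higher numbers for lower toxicity in this test. Compound 1 gives 150000 nM. Compound 2, `Cc1ccc(NC(=O)CSc2nncnc2-c2cccc3ccccc23)c(Br)c1`, gives 166000 nM, and compound 3, `Cc1ccccc1NC(=O)CSc1nncnc1-c1cccc2ccccc12`, gives 158000 nM. The three numbers lie close together: the step of a 1.1-fold higher number from compound 1 to compound 2 (0.04 log units; within the scatter), the step of a 1.1-fold higher number from compound 1 to compound 3 (0.02 log units; within the scatter) and the step of a 1.1-fold lower number from compound 2 to compound 3 (0.02 log units; within the scatter) are all within the scatter, so compound 2 cannot be separated from the other two on this read-out, although its number is nominally the highest of the three.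

Compound 4, `NS(=O)(=O)c1ccc(NC(=O)CSc2nncnc2-c2cccc3ccccc23)c(Br)c1`, differs from compound 2 in one place: sulfamoyl in place of methyl on an aromatic carbon. Going by the values given here, none of the measured steps touches this position or this kind of group; each replaced the substituents of the ring on the amide-type nitrogen with others, and none of those steps moved this assay beyond the scatter. Among the compounds with values here, there is thus no measured step that bears directly on a sulfamoyl for a methyl, and the available changes to that ring gave no shift beyond the scatter in this assay.

Compound 4 is therefore expected to stay close to compound 2, with an estimated step of a 1.0-fold lower number from compound 2 to compound 4 (0.02 log units; within the scatter). The estimate for compound 4 in this assay is 160000 nM, with a range from 80000 nM to 320000 nM.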

Compound 4, half-maximal cytotoxic concentration: 23000 nM
For compound 4 the middle estimate is 7.0-fold (0.84 log units) above the measured one, outside the stated range (below it).
By their numbers in this assay, from the lowest: compound 4; then compounds 1, 3 and 2 (each within the scatter of the next).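

At the aromatic carbon meta to a bromo group and para to a large group, sulfamoyl in place of methyl gives a 7.2-fold lower number from compound 2 to compound 4 (0.86 log units; beyond the scatter) in this assay, a shift toward higher toxicity in this test. The earlier steps shown here, all changes to the substituents of the ring on the amide-type nitrogen, stayed within the scatter, so this result shows that the read-out is not insensitive to every change on that ring. Nothing available accounts for the size or direction of this step.

As far as these compounds go, whether the shift is specific to sulfamoyl or would also appear with another group on this carbon, such as a carboxylic acid or an amine, remains open. From the compounds shown here alone, it is also open whether the same exchange would have a similar effect with chloro in place of the bromo group.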